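Hydroxy addition across two macrocyclic cores, one prior example

The source may hold more compounds than are shown below. What is called first, only, known or untested is meant among the compounds shown, and "the series" means these compounds.

Compound 1 `Oc1ccc2cc1Oc1ccc(cc1)CCc1cccc(O)c1Oc1ccc(cc1)CC2` and compound 2 `Oc1ccc2cc1Oc1ccc(cc1)CCc1cccc(O)c1Oc1ccc(cc1O)CC2` share one core and differ in a single place: hydroxy in place of hydrogen on an aromatic carbon. In a functional assay on K562 cells (Homo sapiens) for antiproliferative activity, read by MTT assay, with a stated time of 48 h (on this read-out higher numbers stand for weaker inhibition and lower numbers for stronger inhibition), compound 1 gives 8520 nM, and compound 2 gives 24900 nM; the step is a 2.9-fold higher number from compound 1 to compound 2 (0.47 log units; beyond the scatter). Compound 3 `Oc1ccc2cc1Oc1ccc(cc1)CCc1ccc(O)c(c1)Oc1cccc(c1)CC2` holds the same atoms as compound 1, joined differently; the difference between the two cores is not broken down here. In this assay compound 3 gives 7020 nM, which sits within the scatter of compound 1 and gives a lower number than compound 2.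

Compound 4 `Oc1ccc2cc1Oc1cccc(c1)CCc1ccc(O)c(c1)Oc1ccc(cc1O)CC2`, not yet measured, stands to compound 3 as compound 2 stands to compound 1: hydroxy in place of hydrogen on an aromatic carbon, the same change at the same described place. Within the data shown here, with only one prior example, the expected step for compound 4 is a 2.7-fold higher number from compound 3 to compound 4 (0.43 log units; beyond the scatter), resting on the step of a 2.9-fold higher number from compound 1 to compound 2 (0.47 log units; beyond the scatter) in this assay. Compound 4 is therefore estimated at 19000 nM, expected between 8000 nM and 45000 nM.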

Compound 4, half-maximal inhibitory concentration: 10900 nM
Compound 4: middle estimate off by 1.7-fold (0.24 log units), on the high side; the measured number falls inside the stated range.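

In this assay, hydroxy in place of hydrogen on an aromatic carbon of the core of compound 3 gives a 1.6-fold higher number from compound 3 to compound 4 (0.19 log units; within the scatter), a step that cannot be told from the scatter on its own. Set beside the step on the core of compound 1, it does not differ from it: the same change on two cores in this assay, a 2.9-fold higher number (0.47 log units; beyond the scatter) from compound 1 to compound 2 and a 1.6-fold higher number (0.19 log units; within the scatter) from compound 3 to compound 4, 1.9-fold (0.27 log units) apart, within the scatter of two such steps. The two pairs are compatible with one shared step carrying over between these two cores, but two pairs cannot fix its size, and they show nothing about any third core.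

Open, as far as these compounds go, is whether hydroxy at another ring place gives a comparable step. Also open, from the compounds shown here alone, is what a methoxy group, an amine or a carboxylic acid would give in place of this hydroxy.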